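A Larger Amide-Side Ring on the Core of Compound 2

The compounds below may be only part of what the source reports. "The series", "measured", "known", "first", "only" and "open" are said of these compounds alone.

Compound 1, `COc1cc(C(=O)Nc2c(OS(=O)(=O)c3ccc(C)cc3)c3ccccc3oc2=O)cc(OC)c1OC`: 40000 nM
Compound 2, `Cc1ccc(S(=O)(=O)Oc2c(NC(=O)C3=Cc4ccccc4OC3)c(=O)oc3ccccc23)cc1`: 70000 nM

In a functional assay on MCF7 cells (Homo sapiens) for antiproliferative activity, read by MTT assay, with a stated time of 72 h (a lower number here means a stronger inhibitor, a higher number a weaker inhibitor), compound 1 gives 40000 nM and compound 2 gives 70000 nM. Among the compounds with values here, the single measured step, a 1.8-fold higher number from compound 1 to compound 2 (0.24 log units; within the scatter), lies within the scatter, so compound 2 and compound 1 cannot be told apart on these numbers; both sit at the weak end of what this assay can resolve.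

Compound 3, `Cc1ccc(S(=O)(=O)Oc2c(NC(=O)c3ccc4c(c3)C=CC(C)(C)O4)c(=O)oc3ccccc23)cc1`, differs from compound 2 by a group of 12 heavy atoms (11 carbon, 1 oxygen; one six-membered non-aromatic ring with 1 hetero atom, one six-membered aromatic ring of carbon only) in place of a group of 10 heavy atoms (9 carbon, 1 oxygen; one six-membered non-aromatic ring with 1 hetero atom, one six-membered aromatic ring of carbon only), on a carbonyl carbon. Within the data shown here, no measured step covers this exact exchange. Among the measured compounds shown here, the one step known, from compound 1 to compound 2, also changed the group on the carbonyl carbon and stayed within the scatter, which gives no ground to expect a large move here. The step from compound 2 to compound 3 is therefore expected to be a 1.2-fold lower number from compound 2 to compound 3 (0.07 log units; within the scatter), within the scatter. Compound 3 is estimated at 60000 nM, with a range of 25000 nM to 150000 nM.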

Compound 3, half-maximal inhibitory concentration: 35000 nM
For compound 3 the middle estimate is 1.7-fold (0.23 log units) above the measured one; the range from low to high includes it.
By their numbers in this assay, from the lowest: compounds 3, 1 and 2 (each within the scatter of the next).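

In this assay, putting the group of 12 heavy atoms with its non-aromatic ring on the carbonyl carbon gives a 2.0-fold lower number from compound 2 to compound 3 (0.30 log units; within the scatter), and replacing the group of 12 heavy atoms with only an aromatic ring gives a 1.1-fold lower number from compound 1 to compound 3 (0.06 log units; within the scatter). Three different groups at this place, two with a non-aromatic ring containing one hetero atom and one without, therefore cannot be told apart, and all three compounds remain weak inhibitors in this assay. Nothing available explains this lack of separation.

The compounds shown leave open whether a much smaller or differently built group on this carbonyl carbon, such as a simple alkyl chain, an amine-bearing ring or a carboxylic acid, would shift the number beyond the scatter. Going by these compounds, the rest of the shared core is the same in all three, so the effect of changes elsewhere also remains unknown.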